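The source may report more compounds than this note shows. Statements on the series, on what has been measured and on what is new or still open speak of the compounds shown alone.

Among the measured compounds shown here, in a functional assay on HT-29 cells (Homo sapiens) for cytotoxicity, read by MTT assay (a higher number here means a weaker inhibitor, a lower number a stronger inhibitor), compound 2 `C=C1C(=O)[C@]23C[C@@]1(OC)CC[C@H]2[C@@]12C=CC(=O)[C@](C)(C(=O)O1)[C@H]2[C@@H]3C(=O)OC` gives 80200 nM, the higher of the two numbers measured so far, and compound 1 `C=C1C(=O)[C@]23C[C@@]1(OCC)CC[C@H]2[C@@]12C=CC(=O)[C@](C)(C(=O)O1)[C@H]2[C@@H]3C(=O)OCc1ccccc1` gives 23300 nM, a lower number by a gap beyond the scatter. Compound 3 `C=C1C(=O)[C@]23C[C@@]1(OC)CC[C@H]2[C@@]12C=CC(=O)[C@](C)(C(=O)O1)[C@H]2[C@@H]3C(=O)OCc1ccccc1` differs from compound 2 by phenyl in place of hydrogen on a saturated chain carbon bound to an oxygen next to a carbonyl group, so methoxycarbonyl becomes benzyloxycarbonyl. Compound 1 also carries benzyloxycarbonyl and gives 23300 nM, so a move to a lower number, modestly beyond the scatter, is expected in this assay. The estimated change is a 2.7-fold lower number from compound 2 to compound 3 (0.43 log units; beyond the scatter). For compound 3 the expected value is 30000 nM, with an estimated range from 13000 nM to 65000 nM.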

Compound 3, half-maximal inhibitory concentration: 48400 nM
For compound 3 the middle estimate is 1.6-fold (0.21 log units) below the measured one; low and high end bracket the measured number.
By their numbers in this assay, from the lowest: compound 1; then compounds 3 and 2 (each within the scatter of the next).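

In this assay, phenyl in place of hydrogen on a saturated chain carbon bound to an oxygen next to a carbonyl group gives a 1.7-fold lower number from compound 2 to compound 3 (0.22 log units; within the scatter) and so does not separate the two compounds. Among the compounds shown here, with benzyloxycarbonyl present in both, hydrogen in place of methyl on a saturated chain carbon bound to an oxygen on a saturated carbon gives a 2.1-fold higher number from compound 1 to compound 3 (0.32 log units; beyond the scatter) and is the only modest step beyond the scatter here. Nothing available explains either step. The compounds shown leave open whether a carboxylic acid in place of methoxycarbonyl would shift the number beyond the scatter. They also leave open what a longer chain in place of methyl on that oxygen would do.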